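Allyloxy in place of chloro: expected cytotoxicity of compound 4

The compounds below may be only part of what the source reports. "The series", "measured", "known", "first", "only" and "open" are said of these compounds alone.

Measured so far:
compound 1, `Cc1ccc(S(=O)(=O)NC(=O)Nc2ccccc2C(=O)/C=C/c2ccccc2)cc1`, 25 ug/mL
compound 2, `COc1cc(/C=C/C(=O)c2ccccc2NC(=O)NS(=O)(=O)c2ccc(C)cc2)ccc1O`, 17.8 ug/mL
compound 3, `Cc1ccc(S(=O)(=O)NC(=O)Nc2ccccc2C(=O)/C=C/c2ccc(Cl)cc2)cc1`, 6.92 ug/mL

In an ADME assay on the whole organism for cytotoxicity, with Artemia salina as the target, with a stated time of 24 h (a lower number here means that less compound is needed, a higher number that more compound is needed for the effect), compound 3 stands lowest of the three numbers; the nearest is reached by a 2.6-fold lower number from compound 2 to compound 3 (0.41 log units; beyond the scatter), the furthest by a 3.6-fold lower number from compound 1 to compound 3 (0.56 log units; beyond the scatter).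

Compound 4, `C=CCOc1ccc(/C=C/C(=O)c2ccccc2NC(=O)NS(=O)(=O)c2ccc(C)cc2)cc1`, differs from compound 3 by allyloxy in place of chloro on an aromatic carbon. Going by the values given here, no measured step swaps chloro for an oxygen-bearing group directly. Bearing on it: a 3.6-fold lower number from compound 1 to compound 3 (0.56 log units; beyond the scatter) shows what the chloro brings relative to hydrogen, and a 2.6-fold lower number from compound 2 to compound 3 (0.41 log units; beyond the scatter) shows chloro against a ring carrying oxygen substituents, while a 1.4-fold lower number from compound 1 to compound 2 (0.15 log units; within the scatter) shows such substituents against plain phenyl within the scatter. Loss of the chloro for allyloxy is therefore expected to give a modestly higher number, a 2.0-fold higher number from compound 3 to compound 4 (0.31 log units; beyond the scatter). For compound 4 the estimate is 14 ug/mL, between 6 ug/mL and 32 ug/mL.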

Compound 4, concentration for half-maximal effect: 6.11 ug/mL
Beside the measured number, compound 4's estimate is 2.3-fold (0.36 log units) above it; the range from low to high includes it.
By their numbers in this assay, from the lowest: compounds 4 and 3 (each within the scatter of the next); then compounds 2 and 1 (each within the scatter of the next).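

Allyloxy for chloro on the aromatic carbon para to a large group leaves this assay unmoved: a 1.1-fold lower number from compound 3 to compound 4 (0.05 log units; within the scatter) is the whole step, so the low end of the series does not depend on chloro. The steps of a 4.1-fold lower number from compound 1 to compound 4 (0.61 log units; beyond the scatter) and a 2.9-fold lower number from compound 2 to compound 4 (0.46 log units; beyond the scatter) both lie beyond the scatter, so an oxygen-linked group here can sit with the chloro compound and apart from the 4-hydroxy-3-methoxyphenyl of compound 2. No measured evidence explains why chloro and allyloxy read alike.

Still open, going by these compounds, is whether an amine or a carboxylic acid at this position would keep the number this low. Also open, on these data alone, is whether a longer chain on the oxygen than allyloxy would do the same.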